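Removing the chloro from the anilide of compound 3

A few compounds are considered here, and "the series" means these few. Any claim that something is new, unique, unknown or untested is made for them only; others in the source may bear on it.

Compound 1 `COc1ccc(/C=C2\NC(=O)N(CC(=O)Nc3ccc(OC)cc3)C2=O)cc1` gives < 100000 nM in a functional assay on U-251 cells (Homo sapiens) for inhibition, read by sulforhodamine B assay, with a stated time of 48 h (a higher number here means that more compound is tolerated, a lower number that less compound is tolerated), which is a limit of the assay.
Compound 2 `O=C(CN1C(=O)N/C(=C\c2ccc(Cl)cc2)C1=O)Nc1ccc(Cl)cc1` gives 60300 nM in this assay.
Compound 3 `COc1ccc(/C=C2/NC(=O)N(CC(=O)Nc3cc(C(F)(F)F)ccc3Cl)C2=O)cc1` gives < 100000 nM in this assay, again only a limit.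

Compound 3 therefore stands not at a number but at the limit of < 100000 nM in this assay, at which 2 of the 3 values shown sit. Compound 4 `COc1ccc(/C=C2/NC(=O)N(CC(=O)Nc3cccc(C(F)(F)F)c3)C2=O)cc1` differs from compound 3 by hydrogen in place of chloro on an aromatic carbon. Among the measured compounds shown here, no step between two measured compounds is available to calibrate this change, so no shift beyond the usual scatter is expected from compound 3 to compound 4, and the step that the limit leaves unreadable from compound 3 to compound 4 is estimated to be essentially flat. Compound 4 is expected to give 90000 nM in this assay, within 40000 nM to 200000 nM, most likely reported as a limit.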

Compound 4, concentration lethal to 50% of the cells: < 100000 nM
Compound 4: only a limit was reported; the forecaster's own chance of this, stated with the estimate: 65%; the middle value lies beyond the limit too.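

No step can be read from compound 3 to compound 4, as both results are only limits: the limit of < 100000 nM in this assay, at which 3 of the 4 values shown sit.

The compounds shown leave open whether hydrogen in place of chloro on an aromatic carbon changes the read-out in this assay at all.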